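This account rests on a few compounds, and the source may have more. Where it says the series, first, only, none or still open, it means among the compounds named here.

In a functional assay on NCI-H460 cells (Homo sapiens) for antiproliferative activity, read by CCK-8 assay, with a stated time of 72 h, tested at 8 uM (on this read-out lower numbers stand for a weaker effect and higher numbers for a stronger effect at the one concentration tested), compound 2 `CC(C)n1cnc2c(Nc3cccc(Cl)c3)nc(NCOCc3ccc(C(=O)Nc4ccccc4N)cc3)nc21` gives 43.2%. For the measured compounds named here, this is the second highest of the three numbers measured so far. Compound 1 `CC(C)n1cnc2c(Nc3ccccc3)nc(NCOCc3ccc(C(=O)Nc4ccccc4N)cc3)nc21` gives 34.3%; the step of a number 8.9 percentage points higher from compound 1 to compound 2 (within the scatter) came with chloro in place of hydrogen on an aromatic carbon. Compound 3 `CC(C)n1cnc2c(Nc3cccc(Cl)c3)nc(NCOCc3ccc(/C=C/C(=O)Nc4ccccc4N)cc3)nc21` gives 61.1%; the step of a number 17.9 percentage points higher from compound 2 to compound 3 (beyond the scatter) came with 2-((2-aminophenyl)carbamoyl)ethenyl in place of (2-aminophenyl)carbamoyl on an aromatic carbon.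

Compound 4 `Nc1ccccc1NC(=O)c1ccc(COCNc2nc(Nc3cccc(Cl)c3)c3ncn(C4CCCC4)c3n2)cc1` differs from compound 2 in one place: cyclopentyl in place of isopropyl on an aromatic nitrogen. Both measured steps alter other parts of the shared core, the aromatic carbon bearing chloro and the carbamoyl end of the chain, so neither speaks to what a change at the aromatic nitrogen does. Going by the values given here, with no measured step bearing on this change, there is no ground to expect a shift in either direction beyond the scatter.

Compound 4 is therefore expected to give about 45% in this assay, estimated to lie between 30% and 62%. The expected step of a number 1.8 percentage points higher from compound 2 to compound 4 (within the scatter) is thus estimated to stay within the scatter.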

Compound 4, a percentage reported as inhibition, at one concentration (the size of the read-out at that concentration, not a potency): 49.2%
Beside the measured number, compound 4's estimate is 4.2 percentage points below it; measured number inside the range.
By their numbers in this assay, from the lowest: compounds 1, 2 and 4 (each within the scatter of the next, the first and the last beyond it); then compound 3.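

In this assay, for the compounds shown here, the step of a number 6 percentage points higher from compound 2 to compound 4 (within the scatter) gives the first reading at the aromatic nitrogen of the five-membered ring, a position the earlier compounds left unchanged. On this read-out, isopropyl and cyclopentyl, which brings a five-membered non-aromatic ring of carbon only, cannot be told apart, so this position takes the ring-bearing group with no shift beyond the usual scatter. No measurement offered here explains why the two groups read alike.

Still open, as far as these compounds go, is how this position would respond to a small methyl group, or to a chain ending in an amine or a carboxylic acid. Also unknown is whether cyclopentyl would read the same alongside the 2-((2-aminophenyl)carbamoyl)ethenyl group of compound 3.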